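Chain length at the indole nitrogen in a cytotoxic oxindole series

The compounds below may be only part of what the source reports. "The series", "measured", "known", "first", "only" and "open" are said of these compounds alone.

Measured compounds:
compound 1, `O=C1Nc2ccccc2/C1=C\c1c(Cl)n(Cc2ccccc2)c2ccccc12`: 8910 nM
compound 2, `O=C1/C(=C/c2c(Cl)[nH]c3ccccc23)c2ccccc2N1Cc1ccccc1`: 5130 nM
compound 3, `COc1c(/C=C2/C(=O)Nc3ccccc32)c2ccccc2n1-c1ccccc1`: 1480 nM

All three were run in a functional assay on cells (Melanoma cell, Homo sapiens) for cytotoxicity, with a stated time of 48 h; a higher number here means a weaker inhibitor of growth, a lower number a stronger inhibitor of growth. Compound 1 gives 8910 nM, which sits at the upper end of the three numbers. Compound 2, with 5130 nM, lies within the usual scatter of compound 1, so the two cannot be told apart. Compound 3, with 1480 nM, lies beyond the scatter, at a lower number than compound 1. No pair of these compounds differs in a single place, so no measured step is available to read against.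

Compound 4, `O=C1Nc2ccccc2/C1=C\c1c(Cl)n(CCCc2ccccc2)c2ccccc12`, has not yet been measured. Relative to compound 1 the change is phenethyl in place of phenyl on a saturated chain carbon bound to an aromatic nitrogen; the chain on the aromatic nitrogen grows from benzyl to 3-phenylpropyl while the rest of the core is untouched. Compounds 2 and 3 vary other parts of the scaffold and say nothing direct about this chain. Going by the values given here, with no measured step of this kind, the expected step of a 1.2-fold lower number from compound 1 to compound 4 (0.07 log units; within the scatter) is set at none beyond the scatter, with a modest lean toward a lower number. The expected value for compound 4 in this assay is 7500 nM, within a range from 3000 nM to 20000 nM.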

Compound 4, concentration for 50% growth inhibition: 13800 nM
Estimate against measurement, compound 4: 1.8-fold (0.26 log units) below; the range from low to high includes it.
By their numbers in this assay, from the lowest: compound 3; then compounds 2, 1 and 4 (each within the scatter of the next, the first and the last beyond it).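

The pair compound 1 and compound 4 gives the series its first single-place comparison: in this assay, lengthening the chain on the aromatic nitrogen from benzyl to 3-phenylpropyl gives a 1.5-fold higher number from compound 1 to compound 4 (0.19 log units; within the scatter). The two compounds therefore cannot be told apart, so at this position, with the rest of the core unchanged, phenethyl in place of phenyl on a saturated chain carbon bound to an aromatic nitrogen produces no readable shift in growth inhibition. Nothing at hand offers an explanation for this result.

On these data alone, whether the same flat reading holds for a still longer chain such as 4-phenylbutyl, or for a chain carrying an amine or a carboxylic acid, remains open. As far as these compounds go, compound 3, at 1480 nM, differs from compound 1 in more than one place, so its value cannot be assigned to any one change, and which part of that structure matters for growth inhibition also remains open.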